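A Smaller Ring on the Amide Nitrogen of Compound 2

This account rests on a few compounds, and the source may have more. Where it says the series, first, only, none or still open, it means among the compounds named here.

Measured compounds in an assay on lysate for inhibition of 6-phosphofructo-2-kinase/fructose-2,6-bisphosphatase 3 (Homo sapiens), with stated times of 0.5 min and 45 min; on this read-out higher numbers stand for weaker inhibition and lower numbers for stronger inhibition:
compound 1 `Cn1ccc2ccc(-c3cc(Nc4ccccc4S(=O)(=O)N4CCOCC4)cc4nccnc34)cc21` gives 2640 nM;
compound 2 `CC(=O)N1CCC(NC(=O)c2ccncc2Nc2cc(-c3ccc4ccn(C)c4c3)c3nccnc3c2)CC1` gives 31300 nM.

Among the compounds with values here, of the two numbers known, compound 2 has the higher one, and the gap to compound 1 lies well beyond the usual scatter of this assay, so compound 2 is the weaker inhibitor of the two.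

Compound 3 `CC(=O)N1CCC(NC(=O)c2ccncc2Nc2cc(-c3ccc4ccn(C)c4c3)c3nccnc3c2)C1` has not yet been measured. It differs from compound 2 at one place only: 1-acetylpyrrolidin-3-yl in place of 1-acetylpiperidin-4-yl on an amide-type nitrogen. The rest of the shared core is untouched, and the amide, its carbonyl and the acetyl on the ring nitrogen remain.

Within the data shown here, no measured pair shows what such a ring contraction does in this assay, so the step from compound 2 to compound 3 is expected to stay within the scatter, with no clear direction. Compound 3 is therefore expected to give about 30000 nM in this assay, likely between 10000 nM and 90000 nM, a step of a 1.0-fold lower number from compound 2 to compound 3 (0.02 log units; within the scatter).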

Compound 3, half-maximal inhibitory concentration: > 100000 nM
Compound 3: only a limit was reported; the forecaster's own chance of this, stated with the estimate: 10%; middle value at least 3.3-fold (0.52 log units) from the limit.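

In this assay, putting 1-acetylpyrrolidin-3-yl in place of 1-acetylpiperidin-4-yl on the amide-type nitrogen gives an at least 3.1-fold higher number from compound 2 to compound 3 (0.50 log units; beyond the scatter). Within the data shown here, this is the first pair differing in one place, and it shows that the group on this nitrogen matters: going from a six-membered to a five-membered ring, with the amide and the acetyl kept, weakens inhibition beyond the scatter. The result for compound 3 is a limit of the assay and not a number, so the step has a known minimum but no known full size: the limit of > 100000 nM in this assay, at which 1 of the 3 values shown sits.

Only these two rings have been compared at this position, and both carry an acetyl on the ring nitrogen. Going by these compounds, how a free amine in place of that acetyl, or an open carbon chain in place of the ring, would behave remains open.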